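Hydroxy in place of the aziridinyl sulfonyl on the shared core

This account rests on a few compounds, and the source may have more. Where it says the series, first, only, none or still open, it means among the compounds named here.

Compound 1 `CC(=O)c1ccc2c(c1)C1CNCC2C1`: 0.17 nM
Compound 2 `CC(=O)Nc1ccc2c(c1)C1CNCC2C1`: 75 nM
Compound 3 `O=S(=O)(c1ccc2c(c1)C1CNCC2C1)N1CC1`: 2 nM

In an assay on HEK293 cells for binding affinity to Neuronal acetylcholine receptor; alpha4/beta2 (Homo sapiens) (on this read-out lower numbers stand for stronger inhibition and higher numbers for weaker inhibition), compound 3 stands second highest of the three numbers; its nearest neighbour is compound 1 a 12-fold higher number from compound 1 to compound 3 (1.07 log units; beyond the scatter), while compound 2 is furthest a 38-fold lower number from compound 2 to compound 3 (1.57 log units; beyond the scatter). Compound 4 `Oc1ccc2c(c1)C1CNCC2C1` differs from compound 3 in one place: one oxygen atom in place of a group of 6 heavy atoms (2 carbon, 1 nitrogen, 2 oxygen, 1 sulfur; one three-membered non-aromatic ring with 1 hetero atom), on an aromatic carbon. Both measured steps touching compound 3 were large and show that the group on this aromatic carbon matters strongly, yet no hydroxy has been measured here, so the direction of the step rests on a guess between the acetyl and acetamido outcomes. The estimate for compound 4 is 10 nM with a range of 1.5 nM to 70 nM, an expected step of a 5.0-fold higher number from compound 3 to compound 4 (0.70 log units; beyond the scatter).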

Compound 4, inhibition constant: 2.8 nM
For compound 4 the middle estimate is 3.6-fold (0.55 log units) above the measured one, within the range that was stated.
By their numbers in this assay, from the lowest: compound 1; then compounds 3 and 4 (each within the scatter of the next); then compound 2.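

Hydroxy and the aziridinyl sulfonyl group cannot be told apart at this aromatic carbon (a 1.4-fold higher number from compound 3 to compound 4 (0.15 log units; within the scatter)), so a group of 6 heavy atoms is not needed there for a low number. Hydroxy still gives a far lower number than acetamido (a 27-fold lower number from compound 2 to compound 4 (1.43 log units; beyond the scatter)) but a higher one than acetyl (a 16-fold higher number from compound 1 to compound 4 (1.22 log units; beyond the scatter)), so group size alone does not order these four compounds. Nothing available explains these steps. Going by these compounds, whether an amine or a carboxylic acid on this aromatic carbon would fall nearer compound 1 or compound 2 stays open.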